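Adding a Fluorine to the Central Ring of Compound 1

The source may report more compounds than this note shows. Statements on the series, on what has been measured and on what is new or still open speak of the compounds shown alone.

Compound 1 `Cc1cc(=O)n(-c2ccc(F)cc2)nc1C(=O)Nc1ccc(Oc2ncnc3[nH]ccc23)cc1` is tested in a functional assay on MCF7 cells (Homo sapiens) for cytotoxicity, read by MTT assay, with a stated time of 72 h (on this read-out lower numbers stand for stronger inhibition and higher numbers for weaker inhibition), where it gives 4800 nM, the highest of three numbers that nonetheless all sit within the usual scatter of one another. Compound 2 `Cc1ccc(-n2nc(C(=O)Nc3ccc(Oc4ncnc5[nH]ccc45)cc3)c(C)cc2=O)cc1` gives 3620 nM and compound 3 `Cc1cc(=O)n(-c2cccc(C(F)(F)F)c2)nc1C(=O)Nc1ccc(Oc2ncnc3[nH]ccc23)cc1` gives 4560 nM. The step of a 1.3-fold lower number from compound 1 to compound 2 (0.12 log units; within the scatter) and the step of a 1.1-fold lower number from compound 1 to compound 3 (0.02 log units; within the scatter) each swap the group on the aromatic nitrogen, and neither moves the read-out beyond the scatter. Compound 4 `Cc1cc(=O)n(-c2ccc(F)cc2)nc1C(=O)Nc1ccc(Oc2ncnc3[nH]ccc23)c(F)c1` differs from compound 1 in another part of the molecule: fluoro in place of hydrogen on an aromatic carbon. Among the measured compounds shown here, no measured step touches this position, so the only guidance is that small changes elsewhere have left the assay flat. Compound 4 is therefore expected near 4300 nM, within 1800 nM to 10000 nM, a step of a 1.1-fold lower number from compound 1 to compound 4 (0.05 log units; within the scatter) expected to stay within the scatter.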

Compound 4, half-maximal inhibitory concentration: 24500 nM
The estimate for compound 4 lay 5.7-fold (0.76 log units) below the measured number; the whole stated range lies below it.
By their numbers in this assay, from the lowest: compounds 2, 3 and 1 (each within the scatter of the next); then compound 4.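

In this assay this aromatic carbon, ortho to a large group and meta to a large group, proves sensitive: the step is a 5.1-fold higher number from compound 1 to compound 4 (0.71 log units; beyond the scatter). One added fluoro therefore weakens inhibition beyond the scatter, whereas the swaps on the aromatic nitrogen left the read-out within it. Nothing measured here gives a cause for this loss. The compounds shown leave open how a chloro, methoxy or amino group would behave on this same carbon, and so whether the loss belongs to fluoro alone or to any group placed there.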